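Removing a Methyl Group: Expected Effect on Inhibition

The source may report more compounds than this note shows. Statements on the series, on what has been measured and on what is new or still open speak of the compounds shown alone.

Of the compounds shown here, three sharing one core have been measured in a functional assay, read by spectrophotometry, with a stated time of 1 h; on this read-out higher numbers stand for weaker inhibition and lower numbers for stronger inhibition. Compound 1 `O=c1[nH]c2ccccc2cc1/C=N/c1ccccc1O` gives 1660000 nM. Compound 2 `Cc1ccc2[nH]c(=O)c(/C=N/c3ccccc3O)cc2c1` gives 1350000 nM, and the step of a 1.2-fold lower number from compound 1 to compound 2 (0.09 log units; within the scatter) is within the scatter. Compound 3 `Cc1ccc2[nH]c(=O)c(/C=N/Nc3ccc([N+](=O)[O-])cc3[N+](=O)[O-])cc2c1` gives 749000 nM. This value of compound 3 lies beyond the scatter from the value of compound 1, yet within the scatter of the value of compound 2, so no ranking between compound 2 and compound 3 can be drawn from these numbers.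

Compound 4 `O=c1[nH]c2ccccc2cc1/C=N/Nc1ccc([N+](=O)[O-])cc1[N+](=O)[O-]` has not yet been measured. It differs from compound 3 in one place: hydrogen in place of methyl on an aromatic carbon. Going by the values given here, the only measured step that bears on this is the opposite change, methyl in place of hydrogen, seen as a 1.2-fold lower number from compound 1 to compound 2 (0.09 log units; within the scatter), which stayed within the scatter. Undoing that change is therefore expected to move the number little, perhaps slightly upward. On this basis a step of a 1.2-fold higher number from compound 3 to compound 4 (0.08 log units; within the scatter) is expected. Compound 4 is estimated at 900000 nM, with a range from 450000 nM to 1800000 nM.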

Compound 4, half-maximal inhibitory concentration: 375000 nM
Compound 4: the middle estimate sits 2.4-fold (0.38 log units) above what was measured, and the stated range ends above it.
By their numbers in this assay, from the lowest: compounds 4, 3, 2 and 1 (each within the scatter of the next, the first and the last beyond it).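

Removing the methyl from the aromatic carbon gives a 2.0-fold lower number from compound 3 to compound 4 (0.30 log units; within the scatter), so the exchange of methyl and hydrogen at this position also stays within the scatter on a second core. Until now, this change had been seen only between compound 1 and compound 2, and a single pair could not show whether it would behave the same way elsewhere. Read as methyl in place of hydrogen, the two steps point in opposite directions, but neither the steps nor the gap between them stands clear of the scatter, so no consistent direction can be given to this change: the same change on two cores in this assay, a 1.2-fold lower number (0.09 log units; within the scatter) from compound 1 to compound 2 and a 2.0-fold higher number (0.30 log units; within the scatter) from compound 4 to compound 3, 2.5-fold (0.39 log units) apart, within the scatter of two such steps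

The compounds shown carry only hydrogen or methyl at this position, so they say nothing about an amine, a carboxylic acid or a longer chain there. Going by these compounds, whether the exchange of methyl and hydrogen would stay this small on other cores also remains open.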